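The source may hold more compounds than are shown below. What is called first, only, known or untested is meant among the compounds shown, and "the series" means these compounds.

Working notes on the diaryl urea series. Two compounds carry numbers in a functional assay on NCI-H23 cells (Homo sapiens) for inhibition, read by sulforhodamine B assay, with a stated time of 48 h, tested at 10 uM; on this read-out lower numbers stand for a stronger effect and higher numbers for a weaker effect at the one concentration tested. Compound 1 `COc1cc2cc(Oc3ccc(NC(=O)Nc4ccc(C(F)(F)F)cc4)cc3)c(C)nc2cc1OC` gives 79.3% in this assay. Compound 2 `COc1cc2cc(Oc3ccc(NC(=O)Nc4ccc(Cl)c(C(F)(F)F)c4)cc3)c(C)nc2cc1OC` gives 3.46% in this assay, the lowest of the two numbers; the nearest other number belongs to compound 1, and the pair is separated by the step of a number 75.8 percentage points lower from compound 1 to compound 2 (beyond the scatter). Compound 3 `COc1cc2cc(Oc3ccc(NC(=O)Nc4ccc(Cl)c(Cl)c4)cc3)c(C)nc2cc1OC` is not yet measured in this assay. It differs from compound 2 in one place: chloro in place of trifluoromethyl on an aromatic carbon, that is, the 4-chloro-3-(trifluoromethyl)phenyl urea terminus becomes a 3,4-dichlorophenyl one. Within the data shown here, the only measured step, from compound 1 to compound 2, involves a different change, the addition of a chloro group together with relocation of the trifluoromethyl, so it bears on the present exchange only indirectly; no measured pair isolates the trifluoromethyl-to-chloro exchange ortho to a chloro group. Since compound 2 already sits near the floor of the read-out, the step is expected to be small or to run toward a higher number, estimated at a number 11.5 percentage points higher from compound 2 to compound 3 (beyond the scatter). Compound 3 is therefore expected to give about 15% in this assay, within a range from 2% to 55%.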

Compound 3, a percentage reported as activity, at one concentration (the size of the read-out at that concentration, not a potency): 8.26%
Compound 3: the middle estimate sits 6.7 percentage points above what was measured; the measured number falls inside the stated range.
By their numbers in this assay, from the lowest: compounds 2 and 3 (each within the scatter of the next); then compound 1.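

In this assay, replacing trifluoromethyl with chloro ortho to a chloro group gives a number 4.8 percentage points higher from compound 2 to compound 3 (within the scatter), so this position tolerates either group at the single concentration tested, and the read-out does not separate the two termini. The strong effect of compound 2 therefore does not depend on trifluoromethyl at this position: the 3,4-dichlorophenyl terminus also stands well clear of the 4-(trifluoromethyl)phenyl terminus, with a number 71 percentage points lower from compound 1 to compound 3 (beyond the scatter). Nothing available gives a reason for either step.

The read-out was taken at one concentration only, so whether compound 2 and compound 3 would differ in the size of their effect at other concentrations remains unresolved. Also open, going by these compounds, is whether this position accepts only chloro and trifluoromethyl or also a methyl, a methoxy, a nitrile or an amine, and whether any of these would keep the effect seen with compound 2 and compound 3.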